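Pyridin-2-yl in place of 4-methylphenyl on compound 3

The compounds below may be only part of what the source reports. "The series", "measured", "known", "first", "only" and "open" are said of these compounds alone.

Measured in a functional assay on MDA-MB-231 cells (Homo sapiens) for inhibition, read by CCK-8 assay, with a stated time of 48 h; a higher number here means a weaker inhibitor of growth, a lower number a stronger inhibitor of growth:
compound 1 `Cc1ccccc1Nc1nc(Nc2cccnc2)ncc1Cl`: 41200 nM
compound 2 `Cc1ccccc1Nc1nc(NC2CC2)ncc1Cl`: > 100000 nM
compound 3 `Cc1ccc(Nc2ncc(Cl)c(Nc3ccccc3C)n2)cc1`: > 100000 nM

Compound 3 stands at the limit of > 100000 nM in this assay, at which 2 of the 3 values shown sit, so its entry is a limit and not a number. Compound 2 likewise has only a limit. Compound 4 `Cc1ccccc1Nc1nc(Nc2ccccn2)ncc1Cl` has not yet been measured in this assay. Its structural change is pyridin-2-yl in place of 4-methylphenyl on a nitrogen on an aromatic ring. In short, pyridin-2-yl comes in place of 4-methylphenyl on a nitrogen on an aromatic ring.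

The closest measured evidence runs the opposite way. Compound 1 carries pyridin-3-yl where compound 3 carries 4-methylphenyl, and the swap gives an at least 2.4-fold higher number from compound 1 to compound 3 (0.38 log units; beyond the scatter). Cyclopropyl in that place gives an at least 2.4-fold higher number from compound 1 to compound 2 (0.38 log units; beyond the scatter). Between the two limits, the data show a step that the two limits leave unreadable from compound 2 to compound 3. Of these three compounds, only compound 1, the one with a pyridine ring, gives a number, although pyridin-2-yl is not the same group as pyridin-3-yl. A modest move towards a lower number is therefore expected, and compound 4 could still stay at the limit. The expected change is an at least 1.8-fold lower number from compound 3 to compound 4 (0.25 log units; that floor lies within the scatter). For compound 4 the estimated value is 55000 nM, with an expected range of 20000 nM to 100000 nM.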

Compound 4, concentration for 50% growth inhibition: 11200 nM
Estimate against measurement, compound 4: 4.9-fold (0.69 log units) above; the measured number lies below the stated range.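

In this assay, an aromatic ring on this nitrogen is not enough on its own, and the identity of that ring decides the outcome: pyridin-2-yl in place of 4-methylphenyl gives an at least 8.9-fold lower number from compound 3 to compound 4 (0.95 log units; beyond the scatter), and in place of cyclopropyl it gives an at least 8.9-fold lower number from compound 2 to compound 4 (0.95 log units; beyond the scatter). Among these compounds, the earlier compounds offered only one pyridine group, so they could not show that the two pyridine groups differ at this place, yet pyridin-2-yl in place of pyridin-3-yl gives a 3.7-fold lower number from compound 1 to compound 4 (0.57 log units; beyond the scatter). That last step is the only one of the three with a readable size, while the other two are floors, with the true size unknown, as each starts from a compound whose entry is a limit and not a number: the limit of > 100000 nM in this assay, at which 2 of the 4 values shown sit.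

The compounds shown leave open whether pyridin-4-yl or pyrimidin-2-yl on this nitrogen would give a lower number still, and whether a methyl group or an amine on the pyridin-2-yl ring would keep the step. They also leave open whether the step holds when the chlorine on the shared core gives way to fluorine or a methyl group.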